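A few compounds are considered here, and "the series" means these few. Any claim that something is new, unique, unknown or untested is made for them only; others in the source may bear on it.

Measured compounds:
compound 1 `Cc1cc(C)cc(SCc2ccc(/C=C/C(=O)Nc3ccccc3N)cc2)c1` with 2.49%
compound 2 `Cc1ccc(SCc2ccc(C(=O)Nc3ccccc3N)cc2)cc1` with 67%
compound 3 `Nc1ccccc1NC(=O)c1ccc(CSCCc2ccccc2)cc1` with 69.9%

In a functional assay on A-375 cells (Homo sapiens) for inhibition, read by CCK-8 assay, with a stated time of 72 h, tested at 8 uM (a higher number here means more inhibition of growth at the concentration tested, a lower number less inhibition of growth), compound 1 gives the lowest of the three numbers: compound 2 stands a good deal higher, beyond the scatter, and compound 3 higher still, also beyond the scatter. Compound 4 `CC(C)(C)c1ccc(SCc2ccc(/C=C/C(=O)Nc3ccccc3N)cc2)cc1` is not yet measured. It differs from compound 1 in one place: 4-(tert-butyl)phenyl in place of 3,5-dimethylphenyl on a sulfur. Going by the values given here, the only measured step that touches the group on the sulfur is the one from compound 2 to compound 3, a number 2.9 percentage points higher from compound 2 to compound 3 (within the scatter), which lies within the scatter. That step, small as it is, suggests that exchanging the group on the sulfur alone does little, so compound 4 is expected to stay near compound 1, with a step of a number 7.5 percentage points higher from compound 1 to compound 4 (within the scatter) that is not expected to reach beyond the scatter, though the low number of compound 1 leaves room upward. Compound 4 is therefore estimated at 10%, within a range from 0% to 40%.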

Compound 4, percent growth inhibition at one concentration: 35.5%
The estimate for compound 4 lay 25.5 percentage points below the measured number; low and high end bracket the measured number.
By their numbers in this assay, from the lowest: compound 1; then compound 4; then compounds 2 and 3 (each within the scatter of the next).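

In this assay, the group on the sulfur proves able to move the number on the core of compound 1: 4-(tert-butyl)phenyl in place of 3,5-dimethylphenyl gives a number 33 percentage points higher from compound 1 to compound 4 (beyond the scatter), whereas the earlier exchange on the core of compound 2 gave only a number 2.9 percentage points higher from compound 2 to compound 3 (within the scatter). The two groups exchanged here differ little by count, as each has one six-membered aromatic ring of carbon only, no hydrogen-bond donors or acceptors and no net charge, with 10 heavy atoms entering and 8 leaving. Nothing available here explains why this exchange shifts the number.

As far as these compounds go, it remains open whether the same exchange would produce a comparable step on the core of compound 2. Also open, from the compounds shown here alone, is how the number would respond to a group such as a carboxylic acid, an amine or a longer alkyl chain on the sulfur.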